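From bromo to fluoro in an ester series

A few compounds are considered here, and "the series" means these few. Any claim that something is new, unique, unknown or untested is made for them only; others in the source may bear on it.

Measured compounds in a functional assay on the whole organism (strain Kunming) with Mus musculus as the target, in the formalin test, with a stated time of 0.5 h; a higher number here means that more compound is needed for the effect, a lower number that less compound is needed
- compound 1 `COc1cc(OC)c(OC)cc1/C=C/COC(=O)/C=C/c1c(OC)ccc(OC)c1OC` gives a limit of the assay, >= 180 umol/kg
- compound 2 `COc1cc(OC)c(OC)cc1/C=C/COC(=O)/C=C/c1ccc(Br)cc1` gives 243 umol/kg
- compound 3 `COc1cc(OC)c(OC)cc1/C=C/COC(=O)/C=C/c1cc(OC)c(OC)c(OC)c1` gives 192 umol/kg

Only two of these results are true numbers. The result for compound 1 (>= 180 umol/kg) is a limit and not a number. Compound 2 (243 umol/kg) and compound 3 (192 umol/kg) lie within the usual scatter of each other, so neither can be placed ahead of the other. Among the compounds with values here, compound 2 therefore stands level with the only other number available.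

Compound 4 `COc1cc(OC)c(OC)cc1/C=C/COC(=O)/C=C/c1ccc(F)cc1` differs from compound 2 in one place, with fluoro in place of bromo on an aromatic carbon, para to a large group (fluoro in place of bromo on an aromatic carbon). Within the data shown here, no measured pair differs in one place only, so the size of this change has no direct precedent. In this assay the estimated step of a 1.2-fold lower number from compound 2 to compound 4 (0.08 log units; within the scatter) is expected to stay within the scatter. This expectation rests on the closeness of compound 2 (243 umol/kg) and compound 3 (192 umol/kg), which differ in more than one place. In this assay the expected value for compound 4 is 200 umol/kg ( estimated range 100 umol/kg to 400 umol/kg).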

Compound 4, dose for half-maximal effect: 117 umol/kg
Compound 4: middle estimate off by 1.7-fold (0.23 log units), on the high side, and the stated range covers the measured number.
By their numbers in this assay, from the lowest: compounds 4, 3 and 2 (each within the scatter of the next, the first and the last beyond it).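

In this assay, within the data shown here, the exchange of 4-bromophenyl for 4-fluorophenyl gives a 2.1-fold lower number from compound 2 to compound 4 (0.32 log units; beyond the scatter), the first reading of a change made in one place only. The earlier compounds shown here could not show this, since they offered no pair differing in one place; the position on the aromatic carbon, para to a large group, now has one step of its own, and that step shows that the identity of the halogen there can move the dose needed by more than the usual scatter while the rest of the ester stays fixed. The step remains modest and rests on one pair, and nothing shown gives a cause for it.

Compound 1 is a limit of the assay and not a number, so steps involving it cannot be read: the limit of >= 180 umol/kg in this assay, at which 1 of the 4 values shown sits. Still open, as far as these compounds go, is whether the dose follows the halogen alone or any substituent at this place, which a chloro, a nitrile or an amine on the same aromatic carbon would address, along with whether the step carries over to the other aromatic substitution patterns.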